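Fluorophenyl isomers on a shared trimethoxyphenyl core

The source may hold more compounds than are shown below. What is called first, only, known or untested is meant among the compounds shown, and "the series" means these compounds.

Measured so far:
compound 1 `COc1cc(C2=NN(C(C)=O)C(c3cccc(F)c3)O2)cc(OC)c1OC` — 43.5%
compound 2 `COc1ccc(/C=N/NC(=O)c2cc(OC)c(OC)c(OC)c2)c(OC)c1` — 22.2%

Both measured compounds were run in a functional assay on PC-3 cells (Homo sapiens) for antiproliferative activity, read by MTT assay, tested at 5 uM; on this read-out lower numbers stand for a weaker effect and higher numbers for a stronger effect at the one concentration tested. Compound 1 gives 43.5% and stands highest of the two numbers. Compound 2 gives 22.2%, a gap beyond the scatter; the two compounds are not a single-point pair, so nothing more is read from that gap than the two numbers themselves.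

Compound 3 `COc1cc(C2=NN(C(C)=O)C(c3ccccc3F)O2)cc(OC)c1OC` is still to be measured in this assay. It differs from compound 1 in one place: 2-fluorophenyl in place of 3-fluorophenyl on a saturated ring carbon. The two have the same atoms, joined differently.

Among the compounds with values here, no measured pair shows what this change does, so the size of the step is unknown. The expected step is a number 3.5 percentage points lower from compound 1 to compound 3 (within the scatter), that is, none beyond the scatter in either direction. For compound 3 the estimate in this assay is 40%, with a range from 24% to 56%.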

Compound 3, a percentage reported as inhibition, at one concentration (the size of the read-out at that concentration, not a potency): 31.6%
Compound 3: the middle estimate sits 8.4 percentage points above what was measured; the measured number falls inside the stated range.
By their numbers in this assay, from the lowest: compounds 2 and 3 (each within the scatter of the next); then compound 1.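

Moving the fluorine around the phenyl ring, with the atoms themselves unchanged, has a readable effect in this assay: the result is a number 11.9 percentage points lower from compound 1 to compound 3 (beyond the scatter). At this saturated ring carbon, the read-out therefore distinguishes 3-fluorophenyl from 2-fluorophenyl, with the 3-fluorophenyl isomer the higher of this pair, though this rests on a single pair at a single concentration. Nothing available here bears on why the two isomers differ.

The compounds shown leave open how 4-fluorophenyl, an unsubstituted phenyl or a phenyl carrying an amine or a carboxylic acid would read at this ring carbon. They also leave open whether the same isomer order would hold with a group other than fluorine, such as chlorine or methoxy, and whether it would persist across a range of concentrations.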